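The compounds below may be only part of what the source reports. "The series", "measured", "known", "first", "only" and "open" are said of these compounds alone.

Among the measured compounds shown here, compound 2, with the structure `COc1ccc(C(=O)/C=C/c2cc(-c3cc(OC)c(OC)c(OC)c3)n[nH]2)cc1`, stands lowest of the two numbers so far in a functional assay on NCI-H322M cells (Homo sapiens) for cytotoxicity, read by sulforhodamine B assay, with a stated time of 48 h, tested at 0.1 uM (on this read-out lower numbers stand for a stronger effect and higher numbers for a weaker effect at the one concentration tested), where compound 2 gives 96%. Its nearest neighbour is compound 1, with the structure `COc1cc(-c2cc(/C=C/C(=O)c3ccc(N)cc3)[nH]n2)cc(OC)c1OC`, which in this assay gives 103%; the step of a number 7 percentage points lower from compound 1 to compound 2 (within the scatter) is within the scatter, so the two compounds are not distinguished by this read-out. Compound 3, with the structure `COc1cc(-c2cc(/C=C/C(=O)c3ccc(F)c(F)c3)[nH]n2)cc(OC)c1OC`, has not yet been measured. It differs from compound 2 by 3,4-difluorophenyl in place of 4-methoxyphenyl on a carbonyl carbon. For the measured compounds named here, the only measured step that bears on this change is the exchange of methoxy for amino between compound 1 and compound 2, which also alters the aryl group attached to the carbonyl carbon, and that step stayed within the scatter. On this basis no step beyond the scatter is expected for compound 3, and its value in this assay is estimated at 94%, within 72% to 110%, a step of a number 2 percentage points lower from compound 2 to compound 3 (within the scatter).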

Compound 3, a percentage reported as activity, at one concentration (the size of the read-out at that concentration, not a potency): 94%
Estimate against measurement, compound 3: no gap at the digits printed; low and high end bracket the measured number.
By their numbers in this assay, from the lowest: compounds 3, 2 and 1 (each within the scatter of the next).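

The exchange of 4-methoxyphenyl for 3,4-difluorophenyl on a carbonyl carbon gives a number 2 percentage points lower from compound 2 to compound 3 (within the scatter) in this assay, and the exchange of 4-aminophenyl for the same group gives a number 9 percentage points lower from compound 1 to compound 3 (within the scatter). This position now carries three different aryl groups, including one with fluorine in place of the earlier amino and methoxy substituents, and no step among these compounds lies beyond the scatter. Nothing measured here speaks to the reason for this.

As far as these compounds go, at the one concentration tested, the three compounds are not separated, so it stays open whether any group on this carbonyl carbon can shift the read-out. Also open, from the compounds shown here alone, is how a carboxylic acid, a piperidine or a longer alkyl chain in place of the aryl group would read.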